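A few compounds are considered here, and "the series" means these few. Any claim that something is new, unique, unknown or untested is made for them only; others in the source may bear on it.

Measured so far in a functional assay on A549 cells (Homo sapiens) for cytotoxicity, read by MTT assay, with a stated time of 72 h; a higher number here means that more compound is needed for the effect, a lower number that less compound is needed:
- compound 1 `CCc1cccc2c(O)c(-c3occ(C)c3C(=O)O)ccc12`: 10.6 ug/mL
- compound 2 `CCCOC(=O)c1c(C)coc1-c1ccc2c(CC)cccc2c1OC`: > 10 ug/mL (a limit, not a number)
- compound 3 `CCc1cccc2c(OC)c(-c3occ(C)c3C(=O)On3nnc4ccccc43)ccc12`: > 10 ug/mL (a limit, not a number)

Compound 2 has no number in this assay, only the limit > 10 ug/mL. Its place on the numbers shown is the limit of > 10 ug/mL in this assay, at which 2 of the 3 values shown sit.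

Compound 4 `CCc1cccc2c(OC)c(-c3occ(C)c3CO)ccc12` keeps the shared core and differs from compound 2 in one place: hydroxymethyl in place of propoxycarbonyl on an aromatic carbon. In short, hydroxymethyl stands in place of propoxycarbonyl on an aromatic carbon.

Among the measured compounds shown here, the only measured step that touches this group is a step that the two limits leave unreadable from compound 2 to compound 3, and it therefore offers no size to carry over. For the measured compounds named here, the sole number belongs to compound 1, at 10.6 ug/mL. With compound 1 at 10.6 ug/mL as the only anchor, the expectation for compound 4 stays in that region, and no direction is supported by measurement.

The step expected is a step that the limit leaves unreadable from compound 2 to compound 4, an estimate that rests on no measured size. It is also quite possible that compound 4 will be reported only as a limit. For compound 4 the estimated value is 14 ug/mL, with an expected range from 5 ug/mL to 40 ug/mL.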

Compound 4, concentration for half-maximal effect: 9.6 ug/mL
Compound 4: the middle estimate sits 1.5-fold (0.16 log units) above what was measured, and the stated range covers the measured number.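

In this assay compound 4 gives 9.6 ug/mL, so hydroxymethyl on this aromatic carbon of the five-membered aromatic ring with 1 oxygen yields a measured number, and the propoxycarbonyl group is not needed for one. Compound 2 has only a limit and not a number: the limit of > 10 ug/mL in this assay, at which 2 of the 4 values shown sit. Read against that limit, the exchange gives an at least 1.0-fold lower number from compound 2 to compound 4 (0.01 log units; that floor lies within the scatter), so the step has only a floor and its true size stays unknown; the data therefore do not show that hydroxymethyl lowers the number relative to propoxycarbonyl by more than the usual scatter.

The step from compound 2 to compound 3 joins two limits and cannot be read, which leaves no measured size for changes on the oxygen next to the carbonyl group. Still open, as far as these compounds go, is how an aminomethyl group or a longer chain such as hydroxyethyl at this position would compare with hydroxymethyl, and whether any group here can move the number beyond the scatter.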